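Notes on compound 4: bromo gives way to methyl

The source may report more compounds than this note shows. Statements on the series, on what has been measured and on what is new or still open speak of the compounds shown alone.

Three compounds of the series have numbers in a functional assay on T47D cells (Homo sapiens) for antiproliferative activity, read by CCK-8 assay, with a stated time of 72 h; a higher number here means a weaker inhibitor, a lower number a stronger inhibitor. Compound 1 `Cc1nc2c(F)cc(-c3nc(Nc4ccc(NC(=O)C5(C(=O)Nc6cccc(F)c6)CC5)cc4)ncc3F)cc2n1C(C)C` gives 29.3 nM. Compound 2 `Cc1cccc(NC(=O)C2(C(=O)Nc3ccc(Nc4ncc(F)c(-c5cc(F)c6nc(C)n(C(C)C)c6c5)n4)cc3)CC2)c1` gives 203 nM; the one-point step between these two is a 6.9-fold higher number from compound 1 to compound 2 (0.84 log units; beyond the scatter), a change that raised the number beyond the scatter. Compound 3 `Cc1nc2c(F)cc(-c3nc(Nc4ccc(CNC(=O)C5(C(=O)Nc6ccc(Br)cc6)CC5)cc4)ncc3F)cc2n1C(C)C` gives 109 nM, the second highest of the three numbers: compound 2 lies nearest, within the scatter, and compound 1 lies furthest, beyond the scatter at the lower number.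

Compound 4 `Cc1ccc(NC(=O)C2(C(=O)NCc3ccc(Nc4ncc(F)c(-c5cc(F)c6nc(C)n(C(C)C)c6c5)n4)cc3)CC2)cc1` has not been measured. Relative to compound 3 the change is methyl in place of bromo on an aromatic carbon. For the measured compounds named here, no measured pair shows this exact exchange. Going by the values given here, the only measured step in which a halogen is replaced by methyl on the same kind of ring is a 6.9-fold higher number from compound 1 to compound 2 (0.84 log units; beyond the scatter); there the halogen was fluoro and the place on the ring was a different one, so it is only a rough guide, and it points to a higher number. A step in that direction, but smaller in size, is therefore expected for compound 4: a 2.3-fold higher number from compound 3 to compound 4 (0.36 log units; beyond the scatter). Compound 4 is estimated at 250 nM, with a likely range from 80 nM to 800 nM.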

Compound 4, half-maximal inhibitory concentration: 771 nM
Beside the measured number, compound 4's estimate is 3.1-fold (0.49 log units) below it; the measured number falls inside the stated range.
By their numbers in this assay, from the lowest: compound 1; then compounds 3 and 2 (each within the scatter of the next); then compound 4.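

On the 4-bromophenyl of compound 3, methyl in place of bromo keeps the count of heavy atoms and adds no hydrogen-bond donor or acceptor, yet in this assay it gives a 7.1-fold higher number from compound 3 to compound 4 (0.85 log units; beyond the scatter), so this place on the ring responds clearly to the exchange. The step runs in the same direction as a 6.9-fold higher number from compound 1 to compound 2 (0.84 log units; beyond the scatter), where fluoro left a different place on the ring of a different parent; both steps lie beyond the scatter, and so in both measured pairs methyl in place of halogen raises the number, with no shown pair going against this, though two pairs are a thin base for any rule. No measurement shown here bears on why the number rises at this position.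

The compounds shown leave open whether bromo itself matters at this place, or whether any group other than methyl would also raise the number, for example chloro, methoxy, trifluoromethyl or an amine. They also leave open how bromo and methyl compare at this same place on the parent of compound 1.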